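Swapping neopentyl for 2-fluorophenyl on two related cores

The compounds below may be only part of what the source reports. "The series", "measured", "known", "first", "only" and "open" are said of these compounds alone.

The measured compounds:
compound 1, `O=C(NCc1cc(Cl)ccc1-n1cnnn1)[C@@H]1CC=NN1C(=O)[C@H](O)c1ccccc1F`, in a functional assay on a cell-free system (plasma, Homo sapiens), with a stated time of 3 min (on this read-out higher numbers stand for weaker inhibition and lower numbers for stronger inhibition), compound 1 gives 1100 nM
compound 2, `CC(C)(C)C[C@@H](O)C(=O)N1N=CC[C@H]1C(=O)NCc1cc(Cl)ccc1-n1cnnn1`, in this assay compound 2 gives 590 nM
compound 3, `CC(C)(C)C[C@@H](O)C(=O)N1[C@H](C(=O)NCc2cc(Cl)ccc2-n2cnnn2)C[C@@H]2C[C@@H]21`, in this assay compound 3 gives 570 nM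

Compound 2 and compound 1 share one core and differ by a single change, (2-fluorophenyl in place of neopentyl on a saturated chain carbon bound to a carbonyl carbon and an oxygen on a saturated carbon). That change made a step of a 1.9-fold higher number from compound 2 to compound 1 (0.27 log units; within the scatter). Compound 3 sits on a different core; how its core differs from the core of compound 2 is not broken down here. Its value and that of compound 2 lie within the scatter of each other, as do its value and that of compound 1.

Compound 4, `O=C(NCc1cc(Cl)ccc1-n1cnnn1)[C@@H]1C[C@@H]2C[C@@H]2N1C(=O)[C@H](O)c1ccccc1F`, has not yet been measured. For the measured compounds named here, it differs from compound 3 by 2-fluorophenyl in place of neopentyl on a saturated chain carbon bound to a carbonyl carbon and an oxygen on a saturated carbon, which is the same change as the one from compound 2 to compound 1, at the same place. Starting from compound 3 at 570 nM, a step of about the size seen before is expected, namely a 1.8-fold higher number from compound 3 to compound 4 (0.27 log units; within the scatter), because the earlier step was a 1.9-fold higher number from compound 2 to compound 1 (0.27 log units; within the scatter). Compound 4 is therefore estimated at 1050 nM, with a likely range from 500 nM to 2500 nM.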

Compound 4, half-maximal inhibitory concentration: 770 nM
Estimate against measurement, compound 4: 1.4-fold (0.13 log units) above; the range from low to high includes it.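

In this assay, 2-fluorophenyl in place of neopentyl on the core of compound 3 gives a 1.4-fold higher number from compound 3 to compound 4 (0.13 log units; within the scatter) and so stays within the scatter on this core too. Set side by side, the two steps do not differ, so the change reads alike on both cores: the same change on two cores in this assay, a 1.9-fold higher number (0.27 log units; within the scatter) from compound 2 to compound 1 and a 1.4-fold higher number (0.13 log units; within the scatter) from compound 3 to compound 4, 1.4-fold (0.14 log units) apart, within the scatter of two such steps. For the compounds shown here, this does not show a true effect of the change that carries from core to core, since each step on its own lies within the scatter and only two cores are on hand.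

The compounds shown leave open whether any group at this place, on a saturated chain carbon bound to a carbonyl carbon and an oxygen on a saturated carbon, would move the number beyond the scatter on either core. An amine, a carboxylic acid or a longer chain there could settle this, and a third core would show whether such a step carries over.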